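Swapping Phenyl for Cyclohexyl on an Amide-Type Nitrogen

The source may hold more compounds than are shown below. What is called first, only, known or untested is meant among the compounds shown, and "the series" means these compounds.

Going by the values given here, in an ADME assay on HepG2 cells (Homo sapiens), read by MTT assay, with a stated time of 72 h, in the presence of a further agent that is not named here (a higher number here means a weaker inhibitor, a lower number a stronger inhibitor), compound 2 `O=C(Nc1ccccc1)Oc1ccc(Cl)cc1C(=O)Nc1ccc(F)cc1` gives 3250 nM, the lower of the two numbers so far, while compound 1 `O=C(NCc1ccccc1)Oc1ccc(Cl)cc1C(=O)Nc1ccc(F)cc1` gives 34200 nM. Compound 3 `O=C(NC1CCCCC1)Oc1ccc(Cl)cc1C(=O)Nc1ccc(F)cc1` carries cyclohexyl in place of phenyl on an amide-type nitrogen. Among the compounds with values here, only one measured step bears on this change, phenyl in place of benzyl on that same nitrogen, and it was large: an 11-fold lower number from compound 1 to compound 2 (1.02 log units; beyond the scatter). That single step points towards a higher number once phenyl leaves, though probably a smaller move. The expected change is a 3.1-fold higher number from compound 2 to compound 3 (0.49 log units; beyond the scatter). Compound 3 is estimated at 10000 nM, within a range from 2500 nM to 40000 nM.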

Compound 3, half-maximal inhibitory concentration: 8600 nM
For compound 3 the middle estimate is 1.2-fold (0.07 log units) above the measured one; low and high end bracket the measured number.
By their numbers in this assay, from the lowest: compound 2; then compound 3; then compound 1.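

In this assay, an aromatic ring on this amide-type nitrogen is not essential, since replacing phenyl with non-aromatic cyclohexyl gives only a modest change, with a 2.6-fold higher number from compound 2 to compound 3 (0.42 log units; beyond the scatter). Cyclohexyl also keeps a clear advantage over benzyl, with a 4.0-fold lower number from compound 1 to compound 3 (0.60 log units; beyond the scatter), although phenyl gives the lowest number of the three. Nothing available explains these differences.

Still open, going by these compounds, is how an open chain such as butyl would compare on this nitrogen. On these data alone, it is equally open what an amine or a carboxylic acid on the phenyl ring would do.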